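Cytotoxicity in a benzylamide series: methoxy replaces cyclopropyl

The source may hold more compounds than are shown below. What is called first, only, known or untested is meant among the compounds shown, and "the series" means these compounds.

Compound 1 `Cc1nc2cc(C(=O)NCc3ccc(F)cc3)nn2c(-c2cc(F)c3c(c2C)CCCO3)c1[C@H](OC(C)(C)C)C(=O)O`: in an ADME assay on MT2 cells (Homo sapiens) for cytotoxicity (on this read-out lower numbers stand for higher toxicity in this test and higher numbers for lower toxicity in this test), compound 1 gives > 40000 nM, which is a limit of the assay.
Compound 2 `Cc1cc(CNC(=O)c2cc3nc(C)c([C@H](OC(C)(C)C)C(=O)O)c(-c4cc(F)c5c(c4C)CCCO5)n3n2)ccc1F`: in this assay compound 2 gives > 40000 nM, again a limit.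
Compound 3 `Cc1nc2cc(C(=O)NCc3ccc(F)c(C4CC4)c3)nn2c(-c2cc(F)c3c(c2C)CCCO3)c1[C@H](OC(C)(C)C)C(=O)O`: in this assay compound 3 gives > 40000 nM, also a limit.

Compound 3 thus stands where every measured value sits, at the limit of > 40000 nM in this assay, at which 3 of the 3 values shown sit, so no number places it relative to the other two. The step to compound 4 `COc1cc(CNC(=O)c2cc3nc(C)c([C@H](OC(C)(C)C)C(=O)O)c(-c4cc(F)c5c(c4C)CCCO5)n3n2)ccc1F` is methoxy in place of cyclopropyl on an aromatic carbon. The measured steps that touch the same aromatic carbon are a step that the two limits leave unreadable from compound 1 to compound 3 and a step that the two limits leave unreadable from compound 2 to compound 3, and the earlier step that the two limits leave unreadable from compound 1 to compound 2; all three are hidden by the limits, so none gives a readable size or direction. In this assay the account therefore expects no step beyond the scatter, and compound 4 is estimated most likely to return a limit again, which would make a number no higher from compound 3 to compound 4 (the limit leaves the size open) unreadable as well. Compound 4 is expected at 40000 nM, with a range from 20000 nM to 80000 nM.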

Compound 4, half-maximal cytotoxic concentration: > 20000 nM
Compound 4: a limit, no number (the forecaster's own chance of this, stated with the estimate: 85%); the middle value is on the limit's open side.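

In this assay compound 4 gives > 20000 nM, a limit and not a number, so its steps from compound 1, compound 2 and compound 3 cannot be read. The compounds shown leave open whether hydrogen, methyl, cyclopropyl or methoxy on this aromatic carbon changes cytotoxicity at all, and at what concentration any of the four becomes toxic to these cells.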